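From 1-carboxy-1-methylethyl to 1-carboxyethyl on compound 1

The compounds below may be only part of what the source reports. "The series", "measured", "known", "first", "only" and "open" are said of these compounds alone.

In an ADME assay on the whole organism (Rattus norvegicus) for pharmacokinetics, using cassette dosing, at a dose of 1 mg/kg by the oral route (a higher number here means that a larger share of the oral dose reaches the circulation, a lower number that a smaller share of the oral dose reaches the circulation), compound 1 `Cc1ccc(Cn2c(=O)n(CC(C)(C)C(=O)O)c(=O)[nH]/c2=N\c2ccc(OC(C)C)c(Cl)c2)cc1` gives 30.7%, the lower of the two numbers at hand. Compound 2 `CC(C)Oc1ccc(/N=c2\[nH]c(=O)n(C[C@@H](O)CO)c(=O)n2Cc2ccc(Cl)cc2)cc1Cl` gives 63%, a gap beyond the usual scatter. Compound 3 `Cc1ccc(Cn2c(=O)n(C[C@H](C)C(=O)O)c(=O)[nH]/c2=N\c2ccc(OC(C)C)c(Cl)c2)cc1` keeps the core of compound 1 but carries 1-carboxyethyl in place of 1-carboxy-1-methylethyl on a saturated chain carbon bound to an aromatic nitrogen. Within the data shown here, no measured pair shows this change, and no step beyond the scatter is expected in this assay, in either direction. The estimated step of a number 0.7 percentage points lower from compound 1 to compound 3 (within the scatter) is accordingly small. Compound 3 is expected at 30%, within a range from 14% to 48%.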

Compound 3, oral bioavailability: 73.1%
For compound 3 the middle estimate is 43.1 percentage points below the measured one, and the stated range ends below it.
By their numbers in this assay, from the lowest: compound 1; then compound 2; then compound 3.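

Among these compounds, on a saturated chain carbon bound to an aromatic nitrogen, 1-carboxyethyl in place of 1-carboxy-1-methylethyl gives, in this assay, a number 42.4 percentage points higher from compound 1 to compound 3 (beyond the scatter), the first single-place comparison at this position. It shows that this position is sensitive in this read-out, even with the carboxy group retained and the rest of the core of compound 1 unchanged. Nothing available explains the step.

The compounds shown leave open how the opposite stereoisomer of 1-carboxyethyl would behave. Also open, from the compounds shown here alone, is whether carboxymethyl, a longer chain bearing the carboxylic acid, or a primary amide in place of that acid would hold the higher number.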